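The source may report more compounds than this note shows. Statements on the series, on what has been measured and on what is new or still open speak of the compounds shown alone.

In a physicochemical assay, with a stated time of 6 min (a higher number here means a weaker inhibitor, a lower number a stronger inhibitor), compound 1 `Cc1ccc(NC(=O)Nc2nc(-c3cc4cc(Br)ccc4o3)cs2)cc1` gives > 200000 nM. That reading is a limit of the assay and not a number, so compound 1 stands at the limit of > 200000 nM in this assay, at which 1 of the 2 values shown sits. Among the measured compounds shown here, the only other compound measured so far, compound 2 `O=C(Nc1ccccc1)Nc1nc(-c2cc3cc([N+](=O)[O-])ccc3o2)cs1`, gives 183000 nM in this assay, which is also a high number and so indicates weak inhibition.

The next compound, compound 3 `COc1ccc(NC(=O)Nc2nc(-c3cc4cc(Br)ccc4o3)cs2)cc1`, keeps the core of compound 1 and carries one change: methoxy in place of methyl on an aromatic carbon, para to a large group, or (methoxy in place of methyl on an aromatic carbon). In other words, 4-methylphenyl becomes 4-methoxyphenyl.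

For the measured compounds named here, no measured pair shows what a swap like this does, so no direction can be favoured, and no step beyond the usual scatter is expected in this assay. Compound 3 is expected to remain weak, in line with compound 2 at 183000 nM. The assay may again report only a limit for compound 3. The expected change is a number no higher from compound 1 to compound 3 (the limit leaves the size open). For compound 3 the estimated value is 200000 nM, with an expected range from 100000 nM to 400000 nM.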

Compound 3, half-maximal inhibitory concentration: > 200000 nM
Compound 3: a limit, no number; the forecaster's own chance of this, stated with the estimate: 60%; the middle value lies on the limit itself.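

Like compound 1, compound 3 reads as a limit of the assay and not as a number, so no step can be read between compound 1 and compound 3: the limit of > 200000 nM in this assay, at which 2 of the 3 values shown sit.

The compounds shown leave open whether methoxy in place of methyl on the aromatic carbon changes the strength of inhibition at all, and if so, in which direction and by how much.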